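The source may report more compounds than this note shows. Statements on the series, on what has been measured and on what is new or still open speak of the compounds shown alone.

Three compounds share one core and differ only in the aryl group attached to the carbonyl carbon. Compound 1 `COc1ccc(-c2cc3ccccc3nc2/C=C/C(=O)c2ccc(F)cc2)cc1` carries a 4-fluorophenyl there, compound 2 `COc1ccc(-c2cc3ccccc3nc2/C=C/C(=O)c2ccc(O)cc2)cc1` a 4-hydroxyphenyl and compound 3 `COc1ccc(-c2cc3ccccc3nc2/C=C/C(=O)c2c(OC)cccc2OC)cc1` a 2,6-dimethoxyphenyl. In a functional assay on MDA-MB-231 cells (Homo sapiens) for antiproliferative activity, read by XTT assay, with a stated time of 72 h (a lower number here means a stronger inhibitor, a higher number a weaker inhibitor), compound 1 gives 830 nM, compound 2 gives 6350 nM and compound 3 gives 5630 nM. Compound 2 thus stands at the high end of the three numbers: the step of a 7.7-fold higher number from compound 1 to compound 2 (0.88 log units; beyond the scatter) and the step of a 6.8-fold higher number from compound 1 to compound 3 (0.83 log units; beyond the scatter) both lie beyond the scatter, whereas the step of a 1.1-fold lower number from compound 2 to compound 3 (0.05 log units; within the scatter) does not, so compound 2 and compound 3 cannot be ordered against each other.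

Compound 4 `COc1ccc(-c2cc3ccccc3nc2/C=C/C(=O)c2ccc(OC)c(OC)c2)cc1` is not yet measured. Against compound 2 it differs in one place: 3,4-dimethoxyphenyl in place of 4-hydroxyphenyl on a carbonyl carbon. Within the data shown here, the closest precedent is the step of a 1.1-fold lower number from compound 2 to compound 3 (0.05 log units; within the scatter), where a dimethoxyphenyl, there as 2,6-dimethoxyphenyl rather than 3,4-dimethoxyphenyl, also replaced the 4-hydroxyphenyl on the carbonyl carbon and the number hardly moved. Among the measured compounds shown here, no measured pair isolates the hydroxy on its own. A step of a 1.6-fold lower number from compound 2 to compound 4 (0.20 log units; within the scatter) is therefore expected, a small downward move that may well sit inside the scatter. In this assay compound 4 is expected to give about 4000 nM, within a range from 1500 nM to 10000 nM.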

Compound 4, half-maximal inhibitory concentration: 4790 nM
Compound 4: the middle estimate sits 1.2-fold (0.08 log units) below what was measured; the range from low to high includes it.
By their numbers in this assay, from the lowest: compound 1; then compounds 4, 3 and 2 (each within the scatter of the next).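

In this assay the 3,4-dimethoxyphenyl on the carbonyl carbon gives a number that cannot be separated from that of the 4-hydroxyphenyl (a 1.3-fold lower number from compound 2 to compound 4 (0.12 log units; within the scatter)) or that of the 2,6-dimethoxyphenyl (a 1.2-fold lower number from compound 3 to compound 4 (0.07 log units; within the scatter)), so compounds 2, 3 and 4 form one group, although the entering group has no hydrogen-bond donor where the 4-hydroxyphenyl has one and the two dimethoxyphenyl groups carry their methoxy groups at different ring positions. Only the 4-fluorophenyl stands apart, now against a third aryl group (a 5.8-fold higher number from compound 1 to compound 4 (0.76 log units; beyond the scatter)), so among these four compounds the split at this position is compound 1 against the rest, with no compound going against it. Nothing measured here bears on what lies behind this split.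

Still open, from the compounds shown here alone, is whether the lower number of compound 1 belongs to fluoro in particular, since a plain phenyl, a 4-chlorophenyl or a 4-methoxyphenyl on the same carbonyl carbon could fall with compound 1 or with the other three. Also open, going by these compounds, is how an amine or a carboxylic acid on this ring would behave.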